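A few compounds are considered here, and "the series" means these few. Any claim that something is new, unique, unknown or untested is made for them only; others in the source may bear on it.

Measured compounds:
Compound 1, `Cc1nc(N)sc1CCCN/C(N)=N/C(=O)CCCCCCCCC(=O)/N=C(\N)NCCCc1sc(N)nc1C`: 0.39 nM; 1 nM (2 entries)
Compound 2, `N/C(=N\C(=O)CCCCCCCCC(=O)/N=C(\N)NCCCc1cnc(N)s1)NCCCc1cnc(N)s1`: 5.01 nM
Compound 3, `N/C(=N\C(=O)CCCCCCCCCCCCCCCCCCCCC(=O)/N=C(\N)NCCCc1c[nH]cn1)NCCCc1c[nH]cn1`: 34.7 nM

All three were tested in an in vitro functional assay on Sf9 cells for agonist activity at histamine H2 receptor (Cavia porcellus); a lower number here means that less compound is needed, a higher number that more compound is needed for the effect. Compound 2 holds the lowest of the two single numbers in this assay; compound 3 gives 34.7 nM, a higher number that lies beyond the scatter, while compound 1 contributes several entries rather than one number, as given in the several entries of compound 1 in this assay, 0.39 nM; 1 nM (2 entries).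

Compound 4, `Cc1nc(N)sc1CCCN/C(N)=N/C(=O)CCCCCCCCC(=O)/N=C(\N)NCCCc1cnc(N)s1`, has not yet been measured in this assay. Among the compounds with values here, it differs from compound 2 in one place: methyl in place of hydrogen on an aromatic carbon, on only one of the two rings, whereas compound 1 carries that methyl on both rings.

Within the data shown here, no step between two measured compounds isolates this single change. The nearest guide is that compound 1, bearing both methyls, sits in this assay at 0.39 nM; 1 nM (2 entries), and compound 2 at 5.01 nM. On that basis the step from compound 2 to compound 4 is expected to be modest, at a 2.5-fold lower number from compound 2 to compound 4 (0.40 log units; beyond the scatter), towards a lower number and possibly no larger than the scatter. Compound 4 is accordingly expected to give 2 nM, with a range from 0.6 nM to 6 nM.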

Compound 4, half-maximal effective concentration: 3.47 nM
Compound 4: middle estimate off by 1.7-fold (0.24 log units), on the low side; the range from low to high includes it.
By their numbers in this assay, from the lowest: compounds 4 and 2 (each within the scatter of the next); then compound 3.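

In this assay, placing a methyl on one of the two rings gives a 1.4-fold lower number from compound 2 to compound 4 (0.16 log units; within the scatter), so a methyl on an aromatic carbon, next to the ring nitrogen and next to the ring atom that bears a large group, is accepted on one ring without a step beyond the scatter. The earlier compounds shown here could not show this: compound 1 and compound 2 differ on both rings at once, and no step isolated a single methyl. Compound 4 now stands one change away from each of them, and the one further methyl, on its second ring, is all that separates it from compound 1, whose values read as follows: the several entries of compound 1 in this assay, 0.39 nM; 1 nM (2 entries)

The compounds shown leave open how an ethyl, a chlorine or an amine at this same position would read in this assay, as methyl is the only group seen there besides hydrogen. Within the data shown here, they also leave open whether the single methyl would give a step of similar size on a longer chain than the one shared by compound 2 and compound 4.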